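Urea aryl swap: dichlorophenyl to fluorophenyl on shared core

The compounds below may be only part of what the source reports. "The series", "measured", "known", "first", "only" and "open" are said of these compounds alone.

Three ureas sharing one core have been measured in a functional assay on PC-3 cells (Homo sapiens) for antiproliferative activity, read by MTT assay, with a stated time of 48 h; on this read-out higher numbers stand for weaker inhibition and lower numbers for stronger inhibition. Compound 1 `O=C(Nc1cccc(C(F)(F)F)c1)Nc1nnc(Sc2ncnc3scc(-c4ccncc4)c23)s1` gives 11500 nM, compound 2 `COc1ccc(NC(=O)Nc2nnc(Sc3ncnc4scc(-c5ccncc5)c34)s2)cc1` gives 9900 nM, and compound 3 `O=C(Nc1ccc(Cl)c(Cl)c1)Nc1nnc(Sc2ncnc3scc(-c4ccncc4)c23)s1` gives 3600 nM. Compound 3 therefore stands lowest of the three, with steps of a 3.2-fold lower number from compound 1 to compound 3 (0.50 log units; beyond the scatter) and a 2.8-fold lower number from compound 2 to compound 3 (0.44 log units; beyond the scatter), while the step of a 1.2-fold lower number from compound 1 to compound 2 (0.07 log units; within the scatter) separates the other two only within the scatter. Compound 4 `O=C(Nc1cccc(F)c1)Nc1nnc(Sc2ncnc3scc(-c4ccncc4)c23)s1` has not yet been measured in this assay. It differs from compound 3 by 3-fluorophenyl in place of 3,4-dichlorophenyl on an amide-type nitrogen. Among the compounds with values here, the steps that bear on this change are those from compound 1 and compound 2 to compound 3, both modest and both leading to the 3,4-dichlorophenyl. Since compound 4 moves away from that group to 3-fluorophenyl, a step back towards the numbers of compound 1 and compound 2 is expected, estimated as a 2.2-fold higher number from compound 3 to compound 4 (0.35 log units; beyond the scatter). For compound 4 the expected value in this assay is 8000 nM, with a range from 3500 nM to 18000 nM.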

Compound 4, half-maximal inhibitory concentration: 6600 nM
For compound 4 the middle estimate is 1.2-fold (0.08 log units) above the measured one, and the stated range covers the measured number.
By their numbers in this assay, from the lowest: compounds 3, 4, 2 and 1 (each within the scatter of the next, the first and the last beyond it).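

In this assay, the 3-fluorophenyl group of compound 4 is not separated from any of the other three aryl groups on this amide-type nitrogen: the readings are a 1.8-fold higher number from compound 3 to compound 4 (0.26 log units; within the scatter), a 1.5-fold lower number from compound 2 to compound 4 (0.18 log units; within the scatter) and a 1.7-fold lower number from compound 1 to compound 4 (0.24 log units; within the scatter). The earlier compounds shown here showed the 3,4-dichlorophenyl of compound 3 set apart from the other two groups, but that separation does not extend to 3-fluorophenyl, so compound 3 cannot be called the most active of the four. Fluoro in place of trifluoromethyl, the one change here made on the aromatic ring at a single carbon, likewise gives no step beyond the scatter. From the compounds shown here alone, all four compounds carry a substituted phenyl at this nitrogen, so it remains open how a cyclohexyl group, a longer alkyl chain or a phenyl bearing a carboxylic acid would read. Nothing shown here accounts for any of these steps.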